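Swapping the aryl group on a pyrazolopyridine kinase binder

The compounds below may be only part of what the source reports. "The series", "measured", "known", "first", "only" and "open" are said of these compounds alone.

Compound 2 `CCCS(=O)(=O)Nc1ccc(F)c(C(=O)c2n[nH]c3ncc(-c4ccc(C(C)C)cc4)cc23)c1F` gives 17% in an assay for binding affinity to dual specificity mitogen-activated protein kinase kinase 4 (Homo sapiens), read by KINOMEscan, tested at 100 nM (on this read-out lower numbers stand for a stronger effect and higher numbers for a weaker effect at the one concentration tested), the higher of the two numbers measured, while compound 1 `CCCS(=O)(=O)Nc1ccc(F)c(C(=O)c2n[nH]c3ncc(-c4ccccc4C)cc23)c1F` gives 7%; the step of a number 10 percentage points higher from compound 1 to compound 2 (within the scatter) shows that changing this aryl group moved the read-out only within the scatter. Compound 3 `CCCS(=O)(=O)Nc1ccc(F)c(C(=O)c2n[nH]c3ncc(-c4cccc([N+](=O)[O-])c4)cc23)c1F` differs from compound 2 by 3-nitrophenyl in place of 4-isopropylphenyl on an aromatic carbon. For the measured compounds named here, because the only measured step, a number 10 percentage points higher from compound 1 to compound 2 (within the scatter), stayed within the scatter, a comparably small step is expected here, a number 1 percentage points higher from compound 2 to compound 3 (within the scatter), with wide uncertainty. Compound 3 is therefore estimated at 18%, between 4% and 50%.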

Compound 3, a percentage reported as activity, at one concentration (the size of the read-out at that concentration, not a potency): 15%
Beside the measured number, compound 3's estimate is 3 percentage points above it, within the range that was stated.
By their numbers in this assay, from the lowest: compounds 1, 3 and 2 (each within the scatter of the next).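

In this assay, the step of a number 2 percentage points lower from compound 2 to compound 3 (within the scatter) shows that 3-nitrophenyl, with its nitrogen and oxygen atoms and hydrogen-bond acceptors, can replace the all-carbon 4-isopropylphenyl on this aromatic carbon without a change beyond the scatter. The step of a number 8 percentage points higher from compound 1 to compound 3 (within the scatter) gives the same picture against 2-methylphenyl, so these three aryl groups cannot be told apart on this read-out. Nothing available explains this result. Still open, on these data alone, is whether an amine or a carboxylic acid on the aryl ring, or a longer chain in its place, would give a clearly different number.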